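The source may hold more compounds than are shown below. What is called first, only, known or untested is meant among the compounds shown, and "the series" means these compounds.

Going by the values given here, compound 1, `CC1(C)c2[nH]nc(NC(=O)c3ccccc3)c2CN1Cc1ccccc1`, gives 1240 nM in an assay on Sf21 cells for inhibition of high affinity nerve growth factor receptor (Homo sapiens), read by HTRF, with a stated time of 30 min, in the presence of a further agent that is not named here (on this read-out lower numbers stand for stronger inhibition and higher numbers for weaker inhibition), the highest of the two numbers measured so far. Compound 3, `CC1(C)c2[nH]nc(NC(=O)c3ccccc3)c2CN1Cc1ccc(F)cc1F`, differs from it by 2,4-difluorophenyl in place of phenyl on a saturated chain carbon bound to an amine nitrogen in a ring. Among the compounds with values here, one measured step bears on this change: compound 2, `CC1(C)c2[nH]nc(NC(=O)c3ccccc3)c2CN1Cc1cc(F)cc(F)c1`, gives 190 nM in this assay, and a 6.5-fold lower number from compound 1 to compound 2 (0.81 log units; beyond the scatter). Because a 6.5-fold lower number from compound 1 to compound 2 (0.81 log units; beyond the scatter) was clearly beyond the scatter, a drop is also expected for compound 3. With the two fluorines placed differently, a smaller step is expected for compound 3, estimated as a 3.1-fold lower number from compound 1 to compound 3 (0.49 log units; beyond the scatter). Compound 3 is therefore estimated at 400 nM, within a range of 150 nM to 1200 nM.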

Compound 3, half-maximal inhibitory concentration: 2320 nM
Estimate against measurement, compound 3: 5.8-fold (0.76 log units) below; measured number above the stated range.
By their numbers in this assay, from the lowest: compound 2; then compounds 1 and 3 (each within the scatter of the next).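

Two fluorines on the phenyl do not by themselves move the number: 2,4-difluorophenyl in place of phenyl gives a 1.9-fold higher number from compound 1 to compound 3 (0.27 log units; within the scatter) and so stays level with the parent. Where the fluorines sit matters at this position, as swapping 3,5-difluorophenyl for 2,4-difluorophenyl gives a 12-fold higher number from compound 2 to compound 3 (1.09 log units; beyond the scatter) with the same atoms entering. Nothing measured here explains this gap.

Still open, from the compounds shown here alone, is which fluorine placing drives the gap, and whether a single fluorine, a chlorine or a methoxy group on the phenyl would match 3,5-difluorophenyl.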